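This account rests on a few compounds, and the source may have more. Where it says the series, first, only, none or still open, it means among the compounds named here.

Measured in a functional assay on U-937 cells (Homo sapiens) for cytotoxicity, read by MTT assay, with a stated time of 24 h; on this read-out higher numbers stand for weaker inhibition and lower numbers for stronger inhibition:
compound 1 `CC(=O)Oc1c(Br)cc(Br)cc1Oc1ccc(Br)cc1Br`: 32.3 ug/mL
compound 2 `COc1ccccc1N1CCN(CCCCCOc2c(Br)cc(Br)cc2Oc2ccc(Br)cc2Br)CC1`: 37.5 ug/mL
compound 3 `Cc1ccc(S(=O)(=O)n2nc(N3CCN(CCCCCOc4c(Br)cc(Br)cc4Oc4ccc(Br)cc4Br)CC3)c3cc([N+](=O)[O-])ccc32)cc1`: 68.5 ug/mL

In this assay, compound 1 sits at the low end of these numbers with 32.3 ug/mL. Its value and that of compound 2 lie within the scatter of each other, so the two cannot be separated. Compound 3, at 68.5 ug/mL, has a higher number than compound 1, and that gap lies beyond the scatter.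

The next compound to be tested is compound 4 `C#CCOc1c(Br)cc(Br)cc1Oc1ccc(Br)cc1Br`. It keeps the shared core of compound 1 and has propargyl in place of acetyl on an oxygen on an aromatic ring. Among the compounds with values here, no pair of measured compounds differs in one place only, so no measured step speaks directly to this change. The expectation rests on the narrow spread of the series, which runs from compound 1 at 32.3 ug/mL to compound 3 at 68.5 ug/mL, even though compound 2 and compound 3 carry far larger groups on that oxygen. No shift beyond the scatter is expected, in either direction. The expected 1.0-fold lower number from compound 1 to compound 4 (0.00 log units; within the scatter) is therefore small. For compound 4 the estimated value is 32 ug/mL, with an expected range from 16 ug/mL to 64 ug/mL.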

Compound 4, half-maximal inhibitory concentration: 29.5 ug/mL
The estimate for compound 4 lay 1.1-fold (0.04 log units) above the measured number; measured number inside the range.
By their numbers in this assay, from the lowest: compounds 4, 1, 2 and 3 (each within the scatter of the next, the first and the last beyond it).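

In this assay, within the data shown here, the exchange of acetyl for propargyl on an oxygen on an aromatic ring gives the first single-place comparison: a 1.1-fold lower number from compound 1 to compound 4 (0.04 log units; within the scatter). The two compounds therefore cannot be separated, although the change removes the carbonyl and its hydrogen-bond acceptor and brings in a triple bond in place of a double bond, with the same count of heavy atoms. At this position, then, the read-out does not depend on the acetyl group as such, at least for this one replacement of equal size, and nothing in hand gives a reason for that result.

Going by these compounds, a single step says little about the position as a whole, so it remains open whether a free hydroxyl, a plain methyl ether or a small chain ending in a carboxylic acid on the same oxygen would also stay within the scatter of compound 1. On these data alone, it is equally open how much of the number belongs to the shared core itself, a question that exchanging bromine for chlorine or hydrogen on the rings would address.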